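The compounds below may be only part of what the source reports. "The series", "measured", "known", "first", "only" and "open" are said of these compounds alone.

Measured set in a functional assay on HepG2 cells (Homo sapiens) for antiproliferative activity, read by CCK-8 assay, with a stated time of 72 h; a higher number here means a weaker inhibitor, a lower number a stronger inhibitor:
- compound 1 `COc1ccc(C(=O)Nc2cccc(-c3oc4cc(-c5ccc(F)cc5)ccc4c(=O)c3O)c2)cc1` gives 8420 nM
- compound 2 `O=C(Nc1cccc(-c2oc3cc(-c4ccc(F)cc4)ccc3c(=O)c2O)c1)c1ccc(F)cc1F` gives 26400 nM
- compound 3 `O=C(Nc1cccc(-c2oc3cc(-c4ccc(F)cc4)ccc3c(=O)c2O)c1)c1cccc(F)c1` gives 15500 nM

Compound 1 stands with the lowest number of the three; its gap to compound 3 lies within the scatter, its gap to compound 2 beyond it. The next compound, compound 4 `O=C(Nc1cccc(-c2oc3cc(-c4ccc(F)cc4)ccc3c(=O)c2O)c1)c1ccc(Cl)nc1`, differs from compound 1 by 6-chloropyridin-3-yl in place of 4-methoxyphenyl on a carbonyl carbon. Among the compounds with values here, the steps that bear on this are the two earlier swaps at the same carbonyl carbon: a 3.1-fold higher number from compound 1 to compound 2 (0.50 log units; beyond the scatter) and a 1.8-fold higher number from compound 1 to compound 3 (0.27 log units; within the scatter). Both moved the number upward, one modestly, one within the scatter. Within the data shown here, a 6-chloropyridin-3-yl has no direct precedent here, so a similar upward step is expected for compound 4, about a 1.8-fold higher number from compound 1 to compound 4 (0.25 log units; within the scatter). Compound 4 is therefore estimated at 15000 nM, with a range of 6000 nM to 40000 nM.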

Compound 4, half-maximal inhibitory concentration: 4610 nM
Compound 4: middle estimate off by 3.3-fold (0.51 log units), on the high side; measured number outside the range, below it.
By their numbers in this assay, from the lowest: compounds 4, 1, 3 and 2 (each within the scatter of the next, the first and the last beyond it).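

At this carbonyl carbon, 6-chloropyridin-3-yl separates from both fluorinated phenyl groups in this assay with a 3.4-fold lower number from compound 3 to compound 4 (0.53 log units; beyond the scatter) and a 5.7-fold lower number from compound 2 to compound 4 (0.76 log units; beyond the scatter) as the two steps. Against 4-methoxyphenyl the change gives a 1.8-fold lower number from compound 1 to compound 4 (0.26 log units; within the scatter) and leaves compound 1 and compound 4 unseparated, so a ring with a hetero atom is accepted here without loss. No measurement at hand accounts for these differences. Going by these compounds, whether the ring nitrogen or the chlorine matters stays open. A plain pyridin-3-yl, a 4-chlorophenyl or a saturated amine ring on the same carbonyl carbon would address this.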